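The source may hold more compounds than are shown below. What is called first, only, known or untested is meant among the compounds shown, and "the series" means these compounds.

Working notes on the series, all read in an ADME assay on Huh-7 cells (Homo sapiens) for cytotoxicity, read by a luciferase reporter and WST assay, with a stated time of 3 days; a higher number here means that more compound is tolerated, a lower number that less compound is tolerated. Compound 1 (`O=C(Nc1ccc(Br)cc1)c1c(NO)cc(-c2ccccc2)oc1=O`) gives > 20000 nM, which is a limit and not a number. Compound 2 (`COc1ccc(-c2cc(NO)c(C(=O)Nc3ccc(C)cc3)c(=O)o2)cc1`) gives > 20000 nM, again only a limit. Compound 1 therefore has no exact position in the series, and the measured set shows (the limit of > 20000 nM in this assay, at which 3 of the 3 values shown sit).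

Compound 4 (`CCNC(=O)c1c(NO)cc(-c2ccccc2)oc1=O`) is not yet measured. It differs from compound 1 by ethyl in place of 4-bromophenyl on an amide-type nitrogen.

Among the measured compounds shown here, no measured step is available to size this change. The nearest guide is compound 3 (`CNC(=O)c1c(NO)cc(-c2ccc(Cl)cc2)oc1=O`), with methyl on an amide-type nitrogen, which gives > 20000 nM, also a limit. On that basis, no change beyond the scatter is expected in this assay, and no direction is assigned to the expected a number no higher from compound 1 to compound 4 (the limit leaves the size open). A further limit rather than a number is the likeliest report. For compound 4 the estimate is 20000 nM, with an expected range of 10000 nM to 40000 nM.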

Compound 4, half-maximal cytotoxic concentration: > 20000 nM
Compound 4: no number, only a limit (the forecaster's own chance of this, stated with the estimate: 85%); the middle value sits exactly at the limit.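

Compound 1 and compound 4 each give only a limit in this assay, and no step can be read between them. The compounds shown leave open where any of them would give an exact value, and whether ethyl in place of 4-bromophenyl shifts it: the limit of > 20000 nM in this assay, at which 4 of the 4 values shown sit.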